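The compounds below may be only part of what the source reports. "The series", "measured", "known", "first", "only" and "open" are said of these compounds alone.

Compound 3 `CN(C)/C=N/N=C/c1cn(S(=O)(=O)c2ccc(I)cc2)c2cccc([N+](=O)[O-])c12` gives 6340 nM in a functional assay on HEK293 cells for inhibition of 5-hydroxytryptamine receptor 6 (Homo sapiens), read by calcium flux and cAMP accumulation, with a stated time of 10 min (on this read-out lower numbers stand for stronger inhibition and higher numbers for weaker inhibition), which places it at the upper end of the three numbers recorded, separated from compound 2 only within the scatter. Compound 2 `CN(C)/C=N/N=C/c1cn(S(=O)(=O)c2ccc(F)cc2)c2cccc([N+](=O)[O-])c12` gives 4970 nM, and compound 1 `CN(C)/C=N/N=C/c1cn(S(=O)(=O)c2ccccc2)c2cccc([N+](=O)[O-])c12` gives 1830 nM. Compound 4 `Cc1ccc(S(=O)(=O)n2cc(/C=N/N=C/N(C)C)c3c([N+](=O)[O-])cccc32)cc1` differs from compound 3 by methyl in place of iodo on an aromatic carbon. For the measured compounds named here, the steps that bear on this are a 2.7-fold higher number from compound 1 to compound 2 (0.43 log units; beyond the scatter) and a 3.5-fold higher number from compound 1 to compound 3 (0.54 log units; beyond the scatter), while a 1.3-fold higher number from compound 2 to compound 3 (0.11 log units; within the scatter) lies within the scatter; no measured step exchanges one substituent at that position for another beyond the scatter. Because a 1.3-fold higher number from compound 2 to compound 3 (0.11 log units; within the scatter) is so small, a methyl in place of the iodo is expected to leave the number close to where it is, and the estimated step is a 1.3-fold lower number from compound 3 to compound 4 (0.10 log units; within the scatter). Compound 4 is therefore expected to give about 5000 nM, within a range of 2000 nM to 12000 nM.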

Compound 4, half-maximal inhibitory concentration: 2120 nM
For compound 4 the middle estimate is 2.4-fold (0.37 log units) above the measured one, within the range that was stated.
By their numbers in this assay, from the lowest: compounds 1 and 4 (each within the scatter of the next); then compounds 2 and 3 (each within the scatter of the next).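

Methyl in place of iodo gives a 3.0-fold lower number from compound 3 to compound 4 (0.48 log units; beyond the scatter) and methyl in place of fluoro gives a 2.3-fold lower number from compound 2 to compound 4 (0.37 log units; beyond the scatter) on the same 4-substituted phenyl, so this position can separate two substituents, which the iodo and fluoro pair alone did not show. With a 1.2-fold higher number from compound 1 to compound 4 (0.06 log units; within the scatter) as its step from hydrogen, methyl does not share the rise seen with fluoro and iodo, so that rise is not common to every group tried here. No measurement here accounts for this difference.

From the compounds shown here alone, whether methoxy, an amine or a carboxylic acid at this place would stay with hydrogen and methyl or join fluoro and iodo remains open. So does whether a longer chain such as ethyl would follow methyl.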